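Adding a Third Methoxy Group to a Chalcone Aniline

The source may hold more compounds than are shown below. What is called first, only, known or untested is meant among the compounds shown, and "the series" means these compounds.

Compound 1 `Nc1ccc(/C=C/C(=O)c2ccccc2)cc1` is the simplest member of the set; in a functional assay on FM3A cells (Mus musculus) for antiproliferative activity, with a stated time of 48 h (a higher number here means a weaker inhibitor, a lower number a stronger inhibitor), compound 1 gives 146000 nM. Compound 2 `COc1cccc(C(=O)/C=C/c2ccc(N)cc2)c1` carries methoxy in place of hydrogen on an aromatic carbon and gives 43000 nM in this assay, a step of a 3.4-fold lower number from compound 1 to compound 2 (0.53 log units; beyond the scatter). Compound 3 `COc1ccc(/C=C/C(=O)c2ccc(N)cc2)c(OC)c1` gives 43000 nM; the difference between its core and that of compound 1 is not broken down here. Compound 4 `COc1ccc(/C=C/C(=O)c2ccc(N)cc2)c(OC)c1OC` is not yet measured and differs from compound 3 by methoxy in place of hydrogen on an aromatic carbon, the same kind of change as from compound 1 to compound 2, though here the new group sits ortho to two methoxy groups, which the earlier place did not have. Resting on the step of a 3.4-fold lower number from compound 1 to compound 2 (0.53 log units; beyond the scatter), a smaller gain is expected for compound 4, estimated as a 1.7-fold lower number from compound 3 to compound 4 (0.24 log units; within the scatter) in this assay. Compound 4 is expected to give 25000 nM, within 8000 nM and 70000 nM.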

Compound 4, half-maximal inhibitory concentration: 29000 nM
Beside the measured number, compound 4's estimate is 1.2-fold (0.06 log units) below it, and the stated range covers the measured number.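

In this assay, methoxy in place of hydrogen on an aromatic carbon gives a 1.5-fold lower number from compound 3 to compound 4 (0.17 log units; within the scatter), so on this core the step alone cannot be told from the scatter. Set beside the earlier step, the two do not differ by more than repeated measurements allow: the same change on two cores in this assay, a 3.4-fold lower number (0.53 log units; beyond the scatter) from compound 1 to compound 2 and a 1.5-fold lower number (0.17 log units; within the scatter) from compound 3 to compound 4, 2.3-fold (0.36 log units) apart, within the scatter of two such steps. This shows no measurable difference in how the change carries from one core to the other, but it does not show that the step has the same size on both, and two pairs set no rule for the series.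

The compounds shown leave open how a hydroxyl or an ethoxy group would compare with methoxy at this place. They also leave open whether either core would respond alike to a fluorine atom there.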